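Compound 1 and a smaller chloroalkyl relative

The source may report more compounds than this note shows. Statements on the series, on what has been measured and on what is new or still open speak of the compounds shown alone.

Compound 1 `O=C1O[C@H]([C@@H](O)Cn2cc(CNS(=O)(=O)c3ccc(F)cc3)nn2)C(OCc2ccccc2)=C1OCc1ccccc1`: 22500 nM
Compound 2 `COc1ccccc1-c1cn(C/C=C2\OC(=O)C(OCc3ccccc3)=C2OCc2ccccc2)nn1`: > 100000 nM

Going by the values given here, only two compounds have been tested in a functional assay on A549 cells (Homo sapiens) for antiproliferative activity, read by MTT assay, with a stated time of 72 h (a higher number here means a weaker inhibitor, a lower number a stronger inhibitor), and compound 1 is the only one with an actual number, at 22500 nM. Compound 2 gives > 100000 nM, which is a limit of the assay and not a number.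

The next compound to be tested is compound 3 `O=C1O[C@H]([C@@H](O)Cn2cc(CCCCl)nn2)C(OCc2ccccc2)=C1OCc1ccccc1`, which differs from compound 1 at one place: 2-chloroethyl in place of ((4-fluorophenyl)sulfonyl)amino on a saturated chain carbon bound to an aromatic carbon. Cut one bond further out, the same change reads (((4-fluorophenyl)sulfonyl)amino)methyl to 3-chloropropyl. The rest of the core of compound 1 stays as it is.

Among the compounds with values here, no measured pair in this small set shows the effect of such a change, so the expectation is anchored on compound 1 at 22500 nM. The expected result is a 1.3-fold higher number from compound 1 to compound 3 (0.12 log units; within the scatter), a step in the direction of weaker inhibition but not beyond the usual scatter. The uncertainty is wide, and a result at the limit of the assay cannot be excluded. For compound 3 the estimated value is 30000 nM, with an expected range from 9000 nM to 100000 nM.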

Compound 3, half-maximal inhibitory concentration: 29000 nM
Compound 3: the middle estimate sits 1.0-fold (0.01 log units) above what was measured; measured number inside the range.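

In this assay, putting 2-chloroethyl in place of ((4-fluorophenyl)sulfonyl)amino on a saturated chain carbon bound to an aromatic carbon gives a 1.3-fold higher number from compound 1 to compound 3 (0.11 log units; within the scatter). Going by these compounds alone, this is the first comparison at this place, and it shows that a large difference in the group need not move the value beyond the scatter: 11 heavy atoms give way to 3, and the six-membered aromatic ring, the hydrogen-bond donor and the hydrogen-bond acceptors of the departing group are all gone. Nothing measured here gives a reason for this result.

This single pair does not show whether any group at this place can move the value beyond the scatter, and a primary amine, a carboxylic acid or a longer chain ending in chlorine would each put that to the test. It also leaves open whether the chlorine of compound 3 contributes at all, a question that a plain propyl group in place of 3-chloropropyl on the core of compound 1 would address.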